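The compounds below may be only part of what the source reports. "The series", "measured", "known", "first", "only" and "open" are said of these compounds alone.

Three ureas built on one shared core have been tested in a functional assay on HepG2 cells (Homo sapiens) for inhibition, read by MTT assay, with a stated time of 72 h; a lower number here means a stronger inhibitor, a higher number a weaker inhibitor. Compound 1 `O=C(Nc1cccc(OCc2cn(-c3ccccc3)nn2)c1)Nc1ccc(Cl)c(C(F)(F)F)c1` gives 1780 nM. Compound 2 `CCc1cccc(-n2cc(COc3cccc(NC(=O)Nc4ccc(Cl)c(C(F)(F)F)c4)c3)nn2)c1` gives 37900 nM, and compound 3 `O=C(Nc1cccc(OCc2cn(-c3cccc(F)c3)nn2)c1)Nc1ccc(Cl)c(C(F)(F)F)c1` gives 2120 nM. Among these three numbers compound 3 stands second highest, close to compound 1 and far from compound 2.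

The step to compound 4 `O=C(Nc1cccc(OCc2cn(-c3ccc(C(F)(F)F)cc3)nn2)c1)Nc1ccc(Cl)c(C(F)(F)F)c1` makes one change: 4-(trifluoromethyl)phenyl in place of 3-fluorophenyl on an aromatic nitrogen. Going by the values given here, two measured steps bear on it. Adding a fluoro gave a 1.2-fold higher number from compound 1 to compound 3 (0.08 log units; within the scatter), a step within the scatter, while adding an ethyl gave a 21-fold higher number from compound 1 to compound 2 (1.33 log units; beyond the scatter), a large loss. Exchanging ethyl for fluoro gave an 18-fold lower number from compound 2 to compound 3 (1.25 log units; beyond the scatter). A trifluoromethyl is a group of several heavy atoms, closer in count to the ethyl than to a single fluorine, so a sizeable rise in the number is expected, though smaller than with compound 2. Compound 4 is therefore estimated at 7000 nM, within 2200 nM to 25000 nM, meaning an expected step of a 3.3-fold higher number from compound 3 to compound 4 (0.52 log units; beyond the scatter).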

Compound 4, half-maximal inhibitory concentration: 1800 nM
The estimate for compound 4 lay 3.9-fold (0.59 log units) above the measured number, outside the stated range (below it).
By their numbers in this assay, from the lowest: compounds 1, 4 and 3 (each within the scatter of the next); then compound 2.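

On the phenyl carried by the aromatic nitrogen, a group with more heavy atoms need not cost activity in this assay: the 4-(trifluoromethyl)phenyl gives a 1.2-fold lower number from compound 3 to compound 4 (0.07 log units; within the scatter) and a 1.0-fold higher number from compound 1 to compound 4 (0.00 log units; within the scatter) and both steps lie within the scatter. Compound 2 therefore stands alone among these four, with a 21-fold lower number from compound 2 to compound 4 (1.32 log units; beyond the scatter) as a large step, so the loss seen with 3-ethylphenyl does not extend to every larger substituted phenyl here. Nothing available explains why these groups differ. Still open, on these data alone, is whether the loss in compound 2 follows from the ethyl itself or from where it sits on the phenyl, as the ethyl and the trifluoromethyl appear only in the 3-ethylphenyl and 4-(trifluoromethyl)phenyl forms. As far as these compounds go, how a phenyl carrying an amine, a carboxylic acid or a longer chain such as butyl would behave also remains unknown.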